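Compound 2 and the loss of its methyl group

A few compounds are considered here, and "the series" means these few. Any claim that something is new, unique, unknown or untested is made for them only; others in the source may bear on it.

Measured in a functional assay on A549 cells (Homo sapiens) for cytotoxicity; on this read-out lower numbers stand for stronger inhibition and higher numbers for weaker inhibition
compound 1 `Cc1ccc(C2CN(S(=O)(=O)c3ccccc3)C(=O)N2)cc1` gives > 316000 nM as a limit
compound 2 `Cc1ccc(C2CNC(=O)N2S(=O)(=O)c2ccc3c(c2)CCC3)cc1` gives 90300 nM as a number
compound 3 `Cc1ccc(C2CNC(=O)N2S(=O)(=O)c2ccc(C)cc2)cc1` gives > 302000 nM as a limit

Within the data shown here, compound 2 is the only member of this small set with a number, at 90300 nM in this assay here. The other two results are limits of the assay, so the set offers no second number to rank compound 2 against.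

Next in line is compound 4 `O=C1NCC(c2ccccc2)N1S(=O)(=O)c1ccc2c(c1)CCC2`, which has not yet been measured. It carries hydrogen in place of methyl on an aromatic carbon, para to a large group, which turns 4-methylphenyl to phenyl (hydrogen in place of methyl on an aromatic carbon).

Among the measured compounds shown here, all three measured compounds carry the 4-methylphenyl group, and no measured pair shows what removing its methyl does. The expectation therefore rests on compound 2 at 90300 nM as the starting point and on the small size of the change. In this assay a small step toward weaker inhibition is expected, one not likely to clear the usual scatter. The estimated step is a 1.3-fold higher number from compound 2 to compound 4 (0.12 log units; within the scatter) on this reasoning. For compound 4 the expected value is 120000 nM as a central figure. The estimated range for compound 4 runs from 50000 nM to 290000 nM in this read-out.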

Compound 4, half-maximal inhibitory concentration: 58500 nM
Beside the measured number, compound 4's estimate is 2.1-fold (0.31 log units) above it; the measured number falls inside the stated range.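

Among these compounds, this is the first pair with a number on both sides, so the 4-methylphenyl to phenyl change, on an aromatic carbon para to a large group, can now be read directly. In this assay, the step is a 1.5-fold lower number from compound 2 to compound 4 (0.19 log units; within the scatter), which means that hydrogen in place of methyl at this position gives two compounds that this read-out cannot tell apart, at least with the sulfonyl group that compound 2 and compound 4 share. Nothing shown here bears on the cause of this small step.

As far as these compounds go, compound 1 and compound 3 stand only as limits of this assay, so any steps to them cannot be read, and whether the methyl-to-hydrogen result carries over to other sulfonyl groups stays open. Also open is how this position responds to anything other than methyl and hydrogen, such as an amine, a carboxylic acid or a longer chain, since the compounds shown cover only these two groups there.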